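Swapping the amide's diethylamino for a sulfonylated azetidine

The compounds below may be only part of what the source reports. "The series", "measured", "known", "first", "only" and "open" are said of these compounds alone.

Compound 1 `CCN(CC)C(=O)[C@@H]1CCCN(S(=O)(=O)c2ccc(S(=O)(=O)N(CC)CC)cc2)C1` carries a diethylamide on its saturated ring and, in a functional assay on BXPC-3 cells (Homo sapiens) for inhibition, read by MTT assay, with a stated time of 7 days (on this read-out higher numbers stand for weaker inhibition and lower numbers for stronger inhibition), compound 1 gives 10500 nM. Among the three measured compounds it stands second highest. Compound 2 `CCOC(=O)[C@@H]1C[C@@H](O)CN(S(=O)(=O)c2ccc(S(=O)(=O)N(CC)CC)cc2)C1` gives 10800 nM in this assay, a number so close to compound 1 that the two cannot be told apart. Compound 3 `CCOC(=O)[C@@H]1CCCN(S(=O)(=O)c2ccc(S(=O)(=O)N(CC)CC)cn2)C1`, whose aromatic ring holds a nitrogen, gives 1400 nM in this assay, a lower number that lies beyond the usual scatter from compound 1.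

Compound 4 `CCN(CC)S(=O)(=O)c1ccc(S(=O)(=O)N2CCC[C@@H](C(=O)NC3CN(S(C)(=O)=O)C3)C2)cc1` keeps the core of compound 1 and changes only the amide: (1-(methylsulfonyl)azetidin-3-yl)amino in place of diethylamino on a carbonyl carbon. Among the measured compounds shown here, no measured pair shows this kind of change, so no step size can be read from the data. The expectation is therefore a step of modest size, a 1.5-fold lower number from compound 1 to compound 4 (0.18 log units; within the scatter), leaning toward a somewhat lower number but not clearly beyond the scatter. Compound 4 is estimated to give 7000 nM in this assay, expected to fall between 2500 nM and 20000 nM.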

Compound 4, half-maximal inhibitory concentration: 7400 nM
Compound 4: the middle estimate sits 1.1-fold (0.02 log units) below what was measured; measured number inside the range.
By their numbers in this assay, from the lowest: compound 3; then compounds 4, 1 and 2 (each within the scatter of the next).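

The swap of diethylamino for (1-(methylsulfonyl)azetidin-3-yl)amino on the carbonyl carbon gives a 1.4-fold lower number from compound 1 to compound 4 (0.15 log units; within the scatter) in this assay. This position can therefore take a larger group, one that brings a four-membered ring, a sulfonyl group and a hydrogen-bond donor, with no change beyond the scatter. Nothing available explains why the number holds, so this single step describes the outcome and not its cause.

As far as these compounds go, it remains open which part of the new group matters, for example whether a free azetidin-3-ylamino or an acetyl in place of the methylsulfonyl would read the same. Also open, from the compounds shown here alone, is whether a carboxylic acid on the saturated ring, with no amide at all, would stay within the scatter of compound 1.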